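The source may report more compounds than this note shows. Statements on the series, on what has been measured and on what is new or still open speak of the compounds shown alone.

Measured compounds:
Compound 1 `Cc1cc(Cc2cccc(Cl)c2)c(=O)n(CC(=O)Nc2ccc(Br)cc2)n1`: in an assay on HL-60 cells for agonist activity at N-formyl peptide receptor 3 (Homo sapiens), read by calcium flux (a higher number here means that more compound is needed for the effect, a lower number that less compound is needed), compound 1 gives only a limit, > 50000 nM.
Compound 2 `Cc1cc(Cc2ccoc2)c(=O)n(CC(=O)Nc2ccc(Br)cc2)n1`: compound 2 likewise gives only a limit, > 50000 nM.
Compound 3 `Cc1cc(Cc2ccsc2)c(=O)n(CC(=O)Nc2ccc(Br)cc2)n1`: compound 3 too gives only a limit, > 50000 nM.

Compound 3 therefore stands at the assay limit, and the two other values shown are the same limit; none of the three is a number. All three measured steps are unreadable: a step that the two limits leave unreadable from compound 1 to compound 2, a step that the two limits leave unreadable from compound 1 to compound 3 and a step that the two limits leave unreadable from compound 2 to compound 3 each run between two limits, as summarised in the limit of > 50000 nM in this assay, at which 3 of the 3 values shown sit.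

Compound 4 `Cc1cc(N)c(=O)n(CC(=O)Nc2ccc(Br)cc2)n1` differs from compound 3 by amino in place of (thiophen-3-yl)methyl on an aromatic carbon. Going by the values given here, no measured step touches this position of the core of compound 3, and the steps at the other position give no readable size, so no direction can be drawn from them. With every value shown sitting at the limit, the expectation for compound 4 is that it also reports the limit, meaning an expected step that the limit leaves unreadable from compound 3 to compound 4. The estimate for compound 4 in this assay is 60000 nM, expected range 15000 nM to 200000 nM.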

Compound 4, half-maximal effective concentration: > 50000 nM
Compound 4: no number, only a limit; the forecaster's own chance of this, stated with the estimate: 85%; the middle value lies beyond the limit too.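

In this assay compound 4 gives > 50000 nM, a limit and not a number. Going by these compounds alone, its steps from compound 1, compound 2 and compound 3 cannot be read, so no new step results: the limit of > 50000 nM in this assay, at which 4 of the 4 values shown sit. The compounds shown leave open which change to the shared core, if any, would give a measurable value in this assay.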